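The source may report more compounds than this note shows. Statements on the series, on what has been measured and on what is new or still open speak of the compounds shown alone.

Among the compounds with values here, compound 2 `O=C(Nc1ccc(Oc2cc(C(F)(F)F)cc(C(F)(F)F)c2)cc1)c1cc(Cl)ccc1F` gives 1110 nM in an assay on HEK293 cells for inhibition of Toll-like receptor 8 (Homo sapiens), with a stated time of 16 h (a lower number here means a stronger inhibitor, a higher number a weaker inhibitor), the only true number among the three values shown. Compound 1 `Fc1cccc(Cl)c1CNc1ccc(Oc2cc(C(F)(F)F)cc(C(F)(F)F)c2)cc1` reaches only a limit of the assay in this assay, > 50000 nM. Compound 3 `O=C(Nc1ccc(Oc2cc(C(F)(F)F)cc(C(F)(F)F)c2)cc1)c1ccc(I)cc1F` likewise reaches only a limit in this assay, > 50000 nM. Two of the three values therefore sit at the limit of > 50000 nM in this assay, at which 2 of the 3 values shown sit. Compound 4 `Nc1ccc(C(=O)Nc2ccc(Oc3cc(C(F)(F)F)cc(C(F)(F)F)c3)cc2)c(F)c1` differs from compound 2 in one place: 4-amino-2-fluorophenyl in place of 5-chloro-2-fluorophenyl on a carbonyl carbon. Within the data shown here, two measured steps bear on it: an at least 45-fold lower number from compound 1 to compound 2 (1.65 log units; beyond the scatter) was a large gain, while an at least 45-fold higher number from compound 2 to compound 3 (1.65 log units; beyond the scatter) was a large loss. Among the measured compounds shown here, because an at least 45-fold higher number from compound 2 to compound 3 (1.65 log units; beyond the scatter) is the only precedent for exchanging the group on the carbonyl carbon, the step expected for compound 4 is a 7.2-fold higher number from compound 2 to compound 4 (0.86 log units; beyond the scatter), toward the weaker side, with a real chance of a limit only. The estimate for compound 4 in this assay is 8000 nM, between 1500 nM and 50000 nM.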

Compound 4, half-maximal inhibitory concentration: > 50000 nM
Compound 4: a limit, no number; the forecaster's own chance of this, stated with the estimate: 35%; middle value at least 6.2-fold (0.79 log units) from the limit.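

On the carbonyl carbon, 4-amino-2-fluorophenyl in place of 5-chloro-2-fluorophenyl gives in this assay an at least 45-fold higher number from compound 2 to compound 4 (1.65 log units; beyond the scatter), so the large loss seen with 2-fluoro-4-iodophenyl is not confined to that group. Among the compounds shown, only compound 2 keeps a true number, and the others reach a limit: the limit of > 50000 nM in this assay, at which 3 of the 4 values shown sit. The steps to compound 4 from compound 1 and compound 3 cannot be read, as limits stand at both ends. The compounds shown do not separate the effect of the group from where it sits on the ring. Going by these compounds, whether a nitrile or a methoxy group on that ring would give a true number stays open.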